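Pyrrole-to-thiazole swap with amine change on the oxazolidinone series

This account rests on a few compounds, and the source may have more. Where it says the series, first, only, none or still open, it means among the compounds named here.

Compound 1 `O=C(NC[C@H]1CN(c2ccc(-n3cccc3CN3CCC3)cc2)C(=O)O1)c1ccc(Cl)s1` gives the lowest of the two numbers recorded in an assay on isolated protein (plasma) for inhibition of coagulation factor X (Oryctolagus cuniculus) (on this read-out lower numbers stand for stronger inhibition and higher numbers for weaker inhibition), at 810 nM. Within the data shown here, its only measured neighbour is compound 2 `O=C(NC[C@H]1CN(c2ccc(-n3cccc3CN3CCCCC3)cc2)C(=O)O1)c1ccc(Cl)s1`, which in this assay gives 2890 nM; the step of a 3.6-fold higher number from compound 1 to compound 2 (0.55 log units; beyond the scatter) is modest but beyond the scatter. Compound 3 `CCN(CC)Cc1csc(-c2ccc(N3C[C@H](CNC(=O)c4ccc(Cl)s4)OC3=O)cc2)n1` carries 4-((diethylamino)methyl)-1,3-thiazol-2-yl in place of 2-((azetidin-1-yl)methyl)-1H-pyrrol-1-yl on an aromatic carbon. Among the measured compounds shown here, no measured step covers this change directly: the step from compound 1 to compound 2 only alters the amine ring bound to the saturated chain carbon, whereas the move to compound 3 exchanges the aromatic ring and replaces the cyclic amine by an acyclic one at the same time. For the measured compounds named here, the one step known, a 3.6-fold higher number from compound 1 to compound 2 (0.55 log units; beyond the scatter), shows that a change at the amine alone already shifted the number beyond the scatter, so the double change is expected to move the number at least that far, most likely upward, though the direction is poorly anchored. Compound 3 is therefore estimated at 1500 nM in this assay, within 400 nM to 6000 nM, an expected step of a 1.9-fold higher number from compound 1 to compound 3 (0.27 log units; within the scatter).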

Compound 3, half-maximal inhibitory concentration: 720 nM
Compound 3: middle estimate off by 2.1-fold (0.32 log units), on the high side; the range from low to high includes it.
By their numbers in this assay, from the lowest: compounds 3 and 1 (each within the scatter of the next); then compound 2.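

The step of a 1.1-fold lower number from compound 1 to compound 3 (0.05 log units; within the scatter) in this assay shows that the whole group on this aromatic carbon, para to a large group, can be exchanged without the two numbers parting beyond the scatter, even though the ring, its hetero atoms and the amine all differ at once. Among these compounds, earlier, the only step at this group, a 3.6-fold higher number from compound 1 to compound 2 (0.55 log units; beyond the scatter), came from the amine ring alone; the new pair adds that a 4-((diethylamino)methyl)-1,3-thiazol-2-yl group, with an open-chain amine and a ring sulfur, reads alike to the 2-((azetidin-1-yl)methyl)-1H-pyrrol-1-yl group of compound 1. Nothing available explains this match.

The compounds shown leave open how the step divides between ring and amine: a 1,3-thiazol-2-yl group carrying azetidin-1-ylmethyl, or a 1H-pyrrol-1-yl group carrying diethylaminomethyl, would separate the two. Also open, going by these compounds, is what the amine contributes here, which a morpholine or a carboxylic acid in its place would test.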